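The source may hold more compounds than are shown below. What is called first, only, known or untested is meant among the compounds shown, and "the series" means these compounds.

Three compounds share one core, which carries a carboxy group at the end of a chain. Compound 1 `Cc1c(OCCCCOc2ccccc2C(=O)O)ccc(C(=O)CC2CCCC2)c1O` has no result in an assay on HEK293 cells for positive allosteric modulation of metabotropic glutamate receptor 3 (Rattus norvegicus), read by thallium flux, with a stated time of 2.5 min (on this read-out lower numbers stand for an effect already at smaller amounts and higher numbers for an effect only at larger amounts of compound), and is recorded as "not determined" (no result reported). Compound 2 `Cc1c(OCCCCOCOc2ccc(C(=O)O)cc2)ccc(C(=O)CC2CCCC2)c1O` gives 1910 nM in this assay. Compound 3 `Cc1c(OCCCCOc2ccc(C(=O)O)cc2F)ccc(C(=O)CC2CCCC2)c1O` reaches only a limit of this assay, > 10000 nM, and so it stands at the weak end of what is shown. The step of an at least 5.2-fold higher number from compound 2 to compound 3 (0.71 log units; beyond the scatter) exchanges the chain itself, not a small substituent. The change from compound 3 to compound 4 `Cc1cc(C(=O)O)ccc1OCCCCOc1ccc(C(=O)CC2CCCC2)c(O)c1C` is methyl in place of fluoro on an aromatic carbon. For the measured compounds named here, no measured step concerns a fluoro-to-methyl swap, so it gives no guidance; since compound 3 sits at the limit (the limit of > 10000 nM in this assay, at which 1 of the 3 values shown sits), a number for compound 4 is expected only if the step is favourable. Compound 4 is expected at about 10000 nM, between 3000 nM and 30000 nM, which would mean a number no higher from compound 3 to compound 4 (the limit leaves the size open).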

Compound 4, half-maximal effective concentration: > 10000 nM
Compound 4 ended at the assay's limit; the forecaster's own chance of this, stated with the estimate: 55%; the middle value lies on the limit itself.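

With methyl in place of fluoro, compound 4 gives > 10000 nM in this assay, which is a limit and not a number. The step between the two limits cannot be read, so neither group can be ranked above the other at this position. The 4-carboxy-2-methylphenyl end still gives an at least 5.2-fold higher number from compound 2 to compound 4 (0.71 log units; beyond the scatter), so the weak result appears with fluoro and with methyl alike.

Open, going by these compounds, is what chlorine or methoxy would give on this aromatic carbon, or hydrogen with no substituent at all. Also open is how far below the limit any of these would fall: the limit of > 10000 nM in this assay, at which 2 of the 4 values shown sit.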